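The source may report more compounds than this note shows. Statements on the series, on what has been measured and on what is new or still open speak of the compounds shown alone.

Compound 1 `C[C@H](NC(=O)C1CCOCC1)c1ccc(NC(=O)N2CC(c3cccnc3)C2)cc1` is the starting point. In a physicochemical assay for solubility, read by LC-MS, in phosphate buffer, with a stated time of 24 h, at pH 6.8 (on this read-out lower numbers stand for lower solubility and higher numbers for higher solubility), compound 1 gives 380000 nM. Compound 2 `C[C@H](NC(=O)[C@@H]1CCCN1C)c1ccc(NC(=O)N2CC(c3cccnc3)C2)cc1` carries 1-methylpyrrolidin-2-yl in place of oxan-4-yl on a carbonyl carbon. In this assay compound 2 reaches only a limit of the assay, > 1000000 nM, and not a number. The step is an at least 2.6-fold higher number from compound 1 to compound 2 (0.42 log units; beyond the scatter). Compound 3 `C[C@H](NC(=O)C1CCOCC1)c1ccc(NC(=O)N2CC(c3cncc(N)c3)C2)cc1` differs from compound 1 by amino in place of hydrogen on an aromatic carbon, and in this assay compound 3 gives 440000 nM, a step of a 1.2-fold higher number from compound 1 to compound 3 (0.06 log units; within the scatter). Compound 4 `C[C@H](NC(=O)[C@@H]1CCCN1C)c1ccc(NC(=O)N2CC(c3cncc(N)c3)C2)cc1` is yet to be measured; it differs from compound 3 by 1-methylpyrrolidin-2-yl in place of oxan-4-yl on a carbonyl carbon, the same change as between compound 1 and compound 2, at the same place. The expected step from compound 3 is a 2.7-fold higher number from compound 3 to compound 4 (0.44 log units; beyond the scatter), because compound 1 to compound 2 showed an at least 2.6-fold higher number from compound 1 to compound 2 (0.42 log units; beyond the scatter). Compound 4 is therefore estimated at 1200000 nM, likely reported only as a limit.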

Compound 4, solubility: 820000 nM
Compound 4: the middle estimate sits 1.5-fold (0.17 log units) above what was measured; the measured number falls inside the stated range.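

In this assay, 1-methylpyrrolidin-2-yl in place of oxan-4-yl gives a 1.9-fold higher number from compound 3 to compound 4 (0.27 log units; within the scatter), so on the amino-bearing core the change cannot be told apart from no change, while on the core of compound 1 it gave an at least 2.6-fold higher number from compound 1 to compound 2 (0.42 log units; beyond the scatter). Compound 2 gives only a limit of the assay and not a number, so the true size of that first step cannot be read: the limit of > 1000000 nM in this assay, at which 1 of the 4 values shown sits. The amino change, with 1-methylpyrrolidin-2-yl in place, reads an at least 1.2-fold lower number from compound 2 to compound 4 (0.08 log units; that floor lies within the scatter), which also starts from that limit, and two cores cannot show whether the first change carries over in full or shrinks.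

Still open, on these data alone, is how a carboxylic acid or a primary amine in place of 1-methylpyrrolidin-2-yl would read. Also open, as far as these compounds go, is whether the step holds with a methoxy group in place of the amino group.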